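The source may report more compounds than this note shows. Statements on the series, on what has been measured and on what is new or still open speak of the compounds shown alone.

Measured compounds:
- Compound 1, `CN1CCCCC(n2nc(Cc3ccc(Cl)cc3)c3ccccc3c2=O)C1`: 158 nM
- Compound 2, `O=c1c2ccccc2c(Cc2ccc(Cl)cc2)nn1C[C@H]1CCCN1CCCCCc1ccc(OCCCN2CCCCCC2)cc1`: 50.1 nM

Of the two numbers, compound 1 holds the higher one in an assay for binding affinity to Alpha-1B adrenergic receptor (Homo sapiens); on this read-out lower numbers stand for stronger inhibition and higher numbers for weaker inhibition; compound 2 gives 50.1 nM, and the gap between the two values lies beyond the usual scatter. No single-point comparison between them exists, since the two structures differ in more than one place.

Compound 3, `CN1CCC(n2nc(Cc3ccc(Cl)cc3)c3ccccc3c2=O)CC1`, is the unmeasured partner of compound 1. The change is 1-methylpiperidin-4-yl in place of 1-methylazepan-3-yl on an aromatic nitrogen, a smaller ring carrying its methylated nitrogen, attached at a different ring position, with the donor and acceptor count unchanged. For the measured compounds named here, with no measured pair showing the effect of such a ring change, the direction is uncertain; a step within or only slightly beyond the scatter is expected, in either direction. For compound 3 the estimate is 200 nM, within 60 nM to 700 nM, corresponding to an expected step of a 1.3-fold higher number from compound 1 to compound 3 (0.10 log units; within the scatter).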

Compound 3, inhibition constant: 6.31 nM
For compound 3 the middle estimate is 32-fold (1.50 log units) above the measured one; measured number below the stated range.
By their numbers in this assay, from the lowest: compound 3; then compound 2; then compound 1.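

With the core and the 4-chlorobenzyl group held the same, the result shows that this assay responds strongly to the group on this aromatic nitrogen: 1-methylpiperidin-4-yl in place of 1-methylazepan-3-yl gives a 25-fold lower number from compound 1 to compound 3 (1.40 log units; beyond the scatter) and this large step lies beyond the scatter. The earlier compounds shown here could not show this, since compound 1 and compound 2 differ in more than one place. Both groups have the same hydrogen-bond donor and acceptor counts, so those counts do not separate them, and no evidence at hand bears on the reason for the step.

Ring size and attachment position change together in this single step, so the share of each remains open; 1-methylpiperidin-3-yl and 1-methylazepan-4-yl would separate them. Also open, going by these compounds, is what the methyl on the ring nitrogen contributes, which an ethyl group or a plain hydrogen there would address.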